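Acylguanidine sulfones: methyl to imidazolyl at the ring

The source may report more compounds than this note shows. Statements on the series, on what has been measured and on what is new or still open speak of the compounds shown alone.

Measured so far:
compound 1 `Cc1cc(C)c(S(C)(=O)=O)cc1C(=O)N=C(N)N` — 11 nM
compound 2 `Cc1c(C(=O)N=C(N)N)cc(S(C)(=O)=O)c(C)c1C` — 55 nM

Both values come from a functional assay for inhibition of sodium/hydrogen exchanger (Oryctolagus cuniculus); a lower number here means a stronger inhibitor, a higher number a weaker inhibitor. Within the data shown here, compound 2 gives the highest of the two numbers; its only neighbour is compound 1, and the step of a 5.0-fold higher number from compound 1 to compound 2 (0.70 log units; beyond the scatter) shows what one added methyl on an aromatic carbon cost.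

Compound 3 `Cc1c(C(=O)N=C(N)N)cc(S(C)(=O)=O)c(-n2ccnc2)c1C` has not been measured. It differs from compound 2 by 1H-imidazol-1-yl in place of methyl on an aromatic carbon. Among the measured compounds shown here, no measured step describes an exchange of this kind; the single step known, from compound 1 to compound 2, concerns the addition of a methyl at this position and says nothing about replacing it with a ring. The expectation therefore rests on compound 2 alone, with wide uncertainty in either direction. For compound 3 the estimate is 80 nM, with a range from 20 nM to 320 nM. This estimate means a step of a 1.5-fold higher number from compound 2 to compound 3 (0.16 log units; within the scatter), expected to stay within the scatter.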

Compound 3, half-maximal inhibitory concentration: 290 nM
Beside the measured number, compound 3's estimate is 3.6-fold (0.56 log units) below it; the measured number falls inside the stated range.
By their numbers in this assay, from the lowest: compound 1; then compound 2; then compound 3.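

In this assay, among these compounds, the step of a 5.3-fold higher number from compound 2 to compound 3 (0.72 log units; beyond the scatter) is the first reading at the aromatic carbon ortho to a methylsulfonyl group and para to a group of 6 heavy atoms, and it is beyond the scatter. The step is modest, so at this carbon the five-membered aromatic ring of 1H-imidazol-1-yl, with 5 heavy atoms in place of 1, costs potency without abolishing inhibition. No data shown bear on the reason for this rise.

Still open, as far as these compounds go, is whether the rise belongs to the aromatic ring or to its ring nitrogens, which an amine, a phenyl ring or pyrrolidin-1-yl at this carbon would help to separate. Also open, from the compounds shown here alone, is whether 1H-imidazol-1-yl in place of this methyl on the core of compound 1 gives a step of similar size.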